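The compounds below may be only part of what the source reports. "The series", "measured", "known", "first", "only" and "open" are said of these compounds alone.

Compound 3, `COc1cccc(/C=C/C(=O)c2sc(Nc3cccc(Cl)c3)nc2C)c1`, is one of three close relatives tested in a functional assay on NCI-H460 cells (Homo sapiens) for cytotoxicity, read by MTT assay; a lower number here means a stronger inhibitor, a higher number a weaker inhibitor. In this assay compound 3 gives > 25000 nM, which is a limit of the assay and not a number. Compound 1, `COc1cccc(/C=C/C(=O)c2sc(Nc3ccccc3C)nc2C)c1`, gives > 25000 nM in this assay, again a limit. Compound 2, `Cc1ccc(Nc2nc(C)c(C(=O)/C=C/c3ccccc3Cl)s2)cc1`, gives > 25000 nM in this assay, also a limit. Compound 4, `COc1cccc(/C=C/C(=O)c2sc(Nc3ccc(C)cc3)nc2C)c1`, differs from compound 3 in one place: 4-methylphenyl in place of 3-chlorophenyl on a nitrogen on an aromatic ring. For the measured compounds named here, the only measured step, a step that the two limits leave unreadable from compound 1 to compound 3, cannot be read because of the limit of > 25000 nM in this assay, at which 3 of the 3 values shown sit. Going by the values given here, no measured step therefore tells how large a change to expect. Compound 2 also carries a 4-methylphenyl on that nitrogen and shows a limit. Compound 4 is thus expected to remain at the limit, an estimated step that the limit leaves unreadable from compound 3 to compound 4. For compound 4 the expected value is 30000 nM, between 10000 nM and 100000 nM.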

Compound 4, half-maximal inhibitory concentration: > 25000 nM
Compound 4 gave a limit, no number; the forecaster's own chance of this, stated with the estimate: 85%; the middle value is on the limit's open side.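

No step from compound 1, compound 2 or compound 3 to compound 4 can be read, because all four compounds sit at the same limit: the limit of > 25000 nM in this assay, at which 4 of the 4 values shown sit.

On these data alone, whether any change to these compounds gives a measurable value in this assay stays open.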